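Methoxy pattern on the aromatic ring and cytotoxicity

The source may report more compounds than this note shows. Statements on the series, on what has been measured and on what is new or still open speak of the compounds shown alone.

compound 1, `COc1cc(C=C2C(=O)N(c3ccc(Cl)cc3)N(c3ccc(Cl)cc3)C2=O)cc(OC)c1OC`: 16200 nM in a functional assay on MCF7 cells (Homo sapiens) for cytotoxicity, read by MTT assay, with a stated time of 72 h; on this read-out lower numbers stand for stronger inhibition and higher numbers for weaker inhibition
compound 2, `COc1ccc(C=C2C(=O)N(c3ccc(Cl)cc3)N(c3ccc(Cl)cc3)C2=O)cc1OC`: > 128000 nM, a limit of the assay and not a number
compound 3, `COc1cccc(C=C2C(=O)N(c3ccc(Cl)cc3)N(c3ccc(Cl)cc3)C2=O)c1OC`: 11900 nM

Within this assay the three measured compounds differ only in the methoxy groups on the six-membered aromatic ring of carbon only. From compound 1 to compound 2 the change is hydrogen in place of methoxy on an aromatic carbon. It produces an at least 7.9-fold higher number from compound 1 to compound 2 (0.89 log units; beyond the scatter). Compound 2 sits at the limit of > 128000 nM in this assay, at which 1 of the 3 values shown sits. The next step gives an at least 10-fold lower number from compound 2 to compound 3 (1.03 log units; beyond the scatter). Compound 3 and compound 1 lie within the scatter of each other, so no order is drawn between them; the difference between the two cores is not broken down here.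

Compound 4, `COc1ccccc1C=C1C(=O)N(c2ccc(Cl)cc2)N(c2ccc(Cl)cc2)C1=O`, has not been measured. It differs from compound 3 by hydrogen in place of methoxy on an aromatic carbon. This is the same kind of change as from compound 1 to compound 2, not the same: there the place was also meta to a methoxy group, here it is not. A higher number for compound 4 is expected because the earlier instance shows an at least 7.9-fold higher number from compound 1 to compound 2 (0.89 log units; beyond the scatter). The expected step is a 3.8-fold higher number from compound 3 to compound 4 (0.58 log units; beyond the scatter). Compound 4 is estimated at 45000 nM, between 12000 nM and 130000 nM, with a fair chance that only a limit is reported.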

Compound 4, half-maximal inhibitory concentration: 26300 nM
For compound 4 the middle estimate is 1.7-fold (0.23 log units) above the measured one, and the stated range covers the measured number.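

In this assay, hydrogen in place of methoxy gives a higher number on both cores, so the direction carries over between these two pairs, but the size does not, and on the core of compound 3 the step is a 2.2-fold higher number from compound 3 to compound 4 (0.34 log units; beyond the scatter), which sets it apart from the earlier step: the same change on two cores in this assay, an at least 7.9-fold higher number (0.89 log units; beyond the scatter) from compound 1 to compound 2 and a 2.2-fold higher number (0.34 log units; beyond the scatter) from compound 3 to compound 4, at least 3.5-fold (0.55 log units) apart, beyond the scatter of two such steps.
Compound 2 stands at a limit of the assay and not at a number: the limit of > 128000 nM in this assay, at which 1 of the 4 values shown sits.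
The earlier step and the gap between the two steps are therefore lower bounds only, the 2-methoxyphenyl and 3,4-dimethoxyphenyl compounds are separated by an at least 4.8-fold lower number from compound 2 to compound 4 (0.68 log units; beyond the scatter), and two pairs give neither a rule for other cores nor a cause for the difference in size.

The compounds shown leave open how this change behaves on a core with no further methoxy group on the aromatic ring. They also leave open whether a hydroxy group or an amine in place of the methoxy group would follow the same direction.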